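Replacing a Hydroxy Group with Dimethylamino on the Side Chain

The compounds below may be only part of what the source reports. "The series", "measured", "known", "first", "only" and "open" are said of these compounds alone.

Measured compounds:
compound 1 `Cn1ncc(Cl)c1-c1cc(C(=O)N[C@@H]2CN[C@H](CC(=O)O)C[C@H]2c2ccc(Cl)c(Cl)c2)oc1Cl` — 1.94 nM
compound 2 `Cn1ncc(Cl)c1-c1cc(C(=O)N[C@@H]2CN[C@H](CCO)C[C@H]2c2ccc(Cl)c(Cl)c2)oc1Cl` — 2.74 nM

The two measured compounds share one core and differ only at the end of the chain on the saturated ring. In an assay for inhibition of RAC-alpha serine/threonine-protein kinase (Homo sapiens), read by HTRF, with a stated time of 1 h (on this read-out lower numbers stand for stronger inhibition and higher numbers for weaker inhibition), compound 1 gives 1.94 nM, and compound 2 gives 2.74 nM. The step of a 1.4-fold higher number from compound 1 to compound 2 (0.15 log units; within the scatter) lies within the scatter, so compound 2 stands at the higher of the two numbers without being separable from compound 1.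

Compound 3 `CN(C)CC[C@@H]1C[C@@H](c2ccc(Cl)c(Cl)c2)[C@H](NC(=O)c2cc(-c3c(Cl)cnn3C)c(Cl)o2)CN1` has not yet been measured. It differs from compound 2 by dimethylamino in place of hydroxy on a saturated chain carbon, two bonds along the chain from a saturated ring carbon. Among the compounds with values here, no measured step swaps a hydroxy for a dimethylamino; the only step available at this chain, carboxy to hydroxymethyl, was a 1.4-fold higher number from compound 1 to compound 2 (0.15 log units; within the scatter) and stayed within the scatter. Within the data shown here, with that flat comparison as the sole guide, compound 3 is expected to sit close to compound 2 in this assay. The expected step is a 1.3-fold higher number from compound 2 to compound 3 (0.11 log units; within the scatter), which is within the scatter. Compound 3 is therefore estimated at 3.5 nM, with a range from 1.2 nM to 10 nM.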

Compound 3, half-maximal inhibitory concentration: 3.4 nM
Estimate against measurement, compound 3: 1.0-fold (0.01 log units) above; measured number inside the range.
By their numbers in this assay, from the lowest: compounds 1, 2 and 3 (each within the scatter of the next).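

In this assay the exchange of hydroxy for dimethylamino on a saturated chain carbon, two bonds along the chain from a saturated ring carbon, reads as a 1.2-fold higher number from compound 2 to compound 3 (0.09 log units; within the scatter) and so adds a second comparison at this place, one in which three heavy atoms including a nitrogen enter where a single oxygen leaves. The exchange of carboxy for (dimethylamino)methyl, the widest one among these compounds, reads as a 1.8-fold higher number from compound 1 to compound 3 (0.24 log units; within the scatter) and also stays inside the scatter, so all three end groups now give numbers that cannot be told apart on this read-out, whereas the earlier compounds offered only one such pair, both with oxygen at the chain end. Nothing shown here offers any reason why the numbers stay together.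

The compounds shown leave open whether this flat picture would extend to a primary amine, a cyclic amine such as morpholine, an amide or a longer chain at the same place. They also leave open whether a bare ethyl chain, with no oxygen or nitrogen at its end, would give a number close to these three.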